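A few compounds are considered here, and "the series" means these few. Any claim that something is new, unique, unknown or untested is made for them only; others in the source may bear on it.

Two compounds share a core and differ only in the group on a saturated chain carbon bound to an amine nitrogen in a ring. Compound 1 `O=C(O)C12CC(CN3CCC[C@H](O[C@H](CO)c4cc(Cl)cc(Cl)c4)[C@@H]3c3ccccc3)(C1)C2` gives 12000 nM in an assay on isolated protein for activation of cGMP-dependent protein kinase 1 (Homo sapiens), read by ADP-Glo, with stated times of 30 min and 2 h, in the presence of a further agent that is not named here; a higher number here means that more compound is needed for the effect, a lower number that less compound is needed. Compound 2 `Cc1nc(C(=O)O)ccc1CN1CCC[C@H](O[C@H](CO)c2cc(Cl)cc(Cl)c2)[C@@H]1c1ccccc1` gives 370 nM, the lower of the two numbers, and the step of a 32-fold lower number from compound 1 to compound 2 (1.51 log units; beyond the scatter) shows how strongly this position matters. Compound 3 `O=C(O)c1ccc(CN2CCC[C@H](O[C@H](CO)c3cc(Cl)cc(Cl)c3)[C@@H]2c2ccccc2)c(C2CC2)c1` carries a group of 12 heavy atoms (10 carbon, 2 oxygen; one three-membered non-aromatic ring of carbon only, one six-membered aromatic ring of carbon only) in place of a group of 10 heavy atoms (7 carbon, 1 nitrogen, 2 oxygen; one six-membered aromatic ring with 1 hetero atom), on a saturated chain carbon bound to an amine nitrogen in a ring. Going by the values given here, no measured step covers this change; both compound 2 and compound 3 keep an acid on an aromatic ring. Compound 3 is therefore expected near compound 2, with a 1.2-fold higher number from compound 2 to compound 3 (0.09 log units; within the scatter), estimated at 450 nM and within 120 nM to 2500 nM.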

Compound 3, half-maximal effective concentration: 1800 nM
Compound 3: middle estimate off by 4.0-fold (0.60 log units), on the low side; the measured number falls inside the stated range.
By their numbers in this assay, from the lowest: compound 2; then compound 3; then compound 1.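

Keeping an acid on an aromatic ring does not by itself hold the number down: the change brings a 4.9-fold higher number from compound 2 to compound 3 (0.69 log units; beyond the scatter). Even so, the aromatic group remains better than the group with two four-membered rings, with a 6.7-fold lower number from compound 1 to compound 3 (0.82 log units; beyond the scatter). No measurement here explains either step.

The change swaps the ring with its hetero atom for a ring of carbon only and also brings in the three-membered ring, so the two effects cannot be told apart. A methyl group on the carbon-only aromatic ring would help to separate them.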